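Dipropylamino for dimethylamino on the aniline of compound 1

The source may hold more compounds than are shown below. What is called first, only, known or untested is meant among the compounds shown, and "the series" means these compounds.

Measured compounds:
- compound 1, `CCC(=O)Nc1cccc(Oc2nc(Nc3ccc(N(C)C)cc3OC)ncc2Cl)c1`: 15%
- compound 2, `CCC(=O)Nc1cccc(Oc2nc(Nc3ccc(N(C)C)cc3)ncc2Cl)c1`: 31.7%

Two compounds have numbers in an assay on isolated protein for inhibition of NUAK family SNF1-like kinase 2 (Homo sapiens), read by ADP-Glo, with a stated time of 60 min, tested at 10 uM, in the presence of a further agent that is not named here; a higher number here means more inhibition at the concentration tested (going by the name of the read-out), a lower number less inhibition. Compound 1 stands lowest of the two; in this assay compound 1 gives 15%, and compound 2 gives 31.7%. Among the compounds with values here, the one measured step, a number 16.7 percentage points higher from compound 1 to compound 2 (beyond the scatter), is a modest gain beyond the scatter and concerns only the methoxy group.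

Compound 3, `CCCN(CCC)c1ccc(Nc2ncc(Cl)c(Oc3cccc(NC(=O)CC)c3)n2)c(OC)c1`, has not been measured in this assay. It differs from compound 1 in one place: dipropylamino in place of dimethylamino on an aromatic carbon. The methoxy group of compound 1 is kept. Within the data shown here, no measured step touches the amine, so the step from compound 1 to compound 2 does not bear directly on this change; the only size it offers is that of a single small group alteration elsewhere on the same ring. With nothing to point either way, a step within the scatter is expected, a number 3 percentage points higher from compound 1 to compound 3 (within the scatter). Compound 3 is therefore estimated at 18% in this assay, between 5% and 35%.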

Compound 3, a percentage reported as inhibition, at one concentration (the size of the read-out at that concentration, not a potency): "not active" (no number reported)
Compound 3: no number reported, so the estimate cannot be set against anything.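

In this assay, within the data shown here, compound 3 is recorded as "not active" with no number, so no step from compound 1 to compound 3 can be read. Nothing shown bears on the reason for this result. The compounds shown leave open how much the change from dimethylamino to dipropylamino alters inhibition, and whether any numerical difference exists.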